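The compounds below may be only part of what the source reports. "The series", "measured", "known", "first", "only" and "open" are said of these compounds alone.

Measured so far:
compound 1, `Cc1ccc(NC(=O)c2ccc(/N=N\c3c[nH]c4ccccc34)cc2)c(C)c1` — 76100 nM in a functional assay on HCT-116 cells (Homo sapiens) for inhibition, read by MTT assay, with a stated time of 72 h; a higher number here means a weaker inhibitor, a lower number a stronger inhibitor
compound 2, `COc1ccccc1NC(=O)c1ccc(/N=N\c2c[nH]c3ccccc23)cc1` — 122000 nM in this assay

Within the data shown here, compound 2 is one of only two compounds measured, and its number sits alongside that of compound 1: the single step between them, a 1.6-fold higher number from compound 1 to compound 2 (0.20 log units; within the scatter), lies within the scatter, so no order between the two is established.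

Compound 3, `Cc1cccc(NC(=O)c2ccc(/N=N\c3c[nH]c4ccccc34)cc2)c1`, is not yet measured. It differs from compound 2 by 3-methylphenyl in place of 2-methoxyphenyl on an amide-type nitrogen. Among the measured compounds shown here, the one step on record bears on this only indirectly: the group on the amide-type nitrogen was varied there as well, 2-methoxyphenyl against 2,4-dimethylphenyl, and the number moved by a 1.6-fold higher number from compound 1 to compound 2 (0.20 log units; within the scatter), within the scatter. Nothing shown separates such groups beyond the scatter, so compound 3 is expected to sit a step within the scatter away, a 1.3-fold lower number from compound 2 to compound 3 (0.11 log units; within the scatter), with no direction claimed. Compound 3 is estimated at 95000 nM, with a range from 38000 nM to 240000 nM.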

Compound 3, half-maximal inhibitory concentration: 98900 nM
Compound 3: middle estimate off by 1.0-fold (0.02 log units), on the low side; the range from low to high includes it.
By their numbers in this assay, from the lowest: compounds 1, 3 and 2 (each within the scatter of the next).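

In this assay, 3-methylphenyl in place of 2-methoxyphenyl on the amide-type nitrogen gives (a 1.2-fold lower number from compound 2 to compound 3 (0.09 log units; within the scatter)), and 3-methylphenyl in place of 2,4-dimethylphenyl gives (a 1.3-fold higher number from compound 1 to compound 3 (0.11 log units; within the scatter)). The position now holds three substituted phenyl groups, and every pair among compounds 1, 2 and 3 lies within the scatter, so no order among them is established. This includes the exchange of 2-methoxyphenyl, with its hydrogen-bond acceptor, for 3-methylphenyl, with none, and no evidence is available that bears on this lack of separation.

Still open, from the compounds shown here alone, is whether a different kind of group on the amide-type nitrogen, such as a phenyl carrying a carboxylic acid or an amine, or a longer alkyl chain in place of the phenyl, would move the number beyond the scatter. These compounds also say nothing about changes to the shared core itself.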